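Adding an amino group to the oxime series

The compounds below may be only part of what the source reports. "The series", "measured", "known", "first", "only" and "open" are said of these compounds alone.

Of the compounds shown here, two define the series so far. Compound 1 is `COc1ccc(-c2c(-c3cc(OC)c(OC)c(OC)c3)ssc2=O)cc1[N+](=O)[O-]`, and compound 2 is `COc1ccc(-c2ss/c(=N/O)c2-c2cc(OC)c(OC)c(OC)c2)cc1`. In a functional assay on SGC-7901 cells (Homo sapiens) for antiproliferative activity, read by MTT assay, with a stated time of 72 h (a higher number here means a weaker inhibitor, a lower number a stronger inhibitor), compound 1 reads > 100000 nM, which is a limit of the measurement and not a number. In this assay, among the compounds with values here, compound 2 gives 17400 nM, the one true number available, so it serves as the sole numeric reference point.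

The next compound is compound 3, `COc1ccc(-c2ss/c(=N/O)c2-c2cc(OC)c(OC)c(OC)c2)cc1N`. It differs from compound 2 at one place, amino in place of hydrogen on an aromatic carbon, turning 4-methoxyphenyl into 3-amino-4-methoxyphenyl. The new group stands ortho to a methoxy group and meta to a large group.

Within the data shown here, no measured pair isolates this change, so any forecast is a judgement with wide margins. With compound 2 at 17400 nM, there is ample room for a stronger result in this assay. The expected shift is towards stronger inhibition and beyond the usual scatter, with an estimated 29-fold lower number from compound 2 to compound 3 (1.46 log units; beyond the scatter). For compound 3 the estimated value is 600 nM, with an expected range of 30 nM to 8000 nM.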

Compound 3, half-maximal inhibitory concentration: 4300 nM
Compound 3: the middle estimate sits 7.2-fold (0.86 log units) below what was measured, and the stated range covers the measured number.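

In this assay, within the data shown here, amino in place of hydrogen gives a 4.0-fold lower number from compound 2 to compound 3 (0.61 log units; beyond the scatter), the first step that can be read, and it shows that this aromatic carbon, ortho to a methoxy group and meta to a large group, accepts a substituent without loss of activity. The step is modest, and compound 3 at 4300 nM remains a single data point for this position, so it shows a direction for one group and not a trend. Compound 1 stays outside the comparison, since it differs from the oxime compounds in more than one place and its reading is a limit and not a number: the limit of > 100000 nM in this assay, at which 1 of the 3 values shown sits.

As far as these compounds go, whether the gain belongs to the amino group itself or to any substituent at this position stays open; a hydroxyl, a methylamino, a dimethylamino or an acetamido group on the same carbon would separate these readings. Also open, from the compounds shown here alone, is whether the amino group gives a step of similar size on the core of compound 1, where the oxime is replaced by a carbonyl, and whether the step holds in cell lines other than this one.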